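Chloro to Methyl: Expecting the Next Value

The compounds below may be only part of what the source reports. "The series", "measured", "known", "first", "only" and "open" are said of these compounds alone.

Compound 1 `OC[C@H]1OC(n2cnc3c(-c4ccc(F)c(F)c4)ncnc32)[C@H](O)[C@@H]1O` gives 1400 nM in a functional assay on CCRF-CEM cells (Homo sapiens) for inhibition; on this read-out higher numbers stand for weaker inhibition and lower numbers for stronger inhibition.
Compound 2 `OC[C@H]1OC(n2cnc3c(-c4ccc(Cl)cc4)ncnc32)[C@H](O)[C@@H]1O` gives 900 nM in this assay.

For the measured compounds named here, the only measured step, a 1.6-fold lower number from compound 1 to compound 2 (0.19 log units; within the scatter), stays within the scatter, so compound 2 and compound 1 cannot be told apart on these numbers. Compound 3 `Cc1ccc(-c2ncnc3c2ncn3C2O[C@H](CO)[C@@H](O)[C@H]2O)cc1` differs from compound 2 by methyl in place of chloro on an aromatic carbon. Going by the values given here, that measured step also changed only the substituents on this ring and moved little, and no step yet swaps chloro for methyl. The step from compound 2 to compound 3 is therefore expected to be a 1.1-fold higher number from compound 2 to compound 3 (0.05 log units; within the scatter) in this assay, nothing beyond the scatter. Compound 3 is estimated at 1000 nM, ranging from 400 nM to 2500 nM.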

Compound 3, half-maximal inhibitory concentration: 1500 nM
Compound 3: middle estimate off by 1.5-fold (0.18 log units), on the low side, within the range that was stated.
By their numbers in this assay, from the lowest: compounds 2, 1 and 3 (each within the scatter of the next).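

Chloro and methyl can now be compared directly at this place on the ring, para to a large group. In this assay the swap gives a 1.7-fold higher number from compound 2 to compound 3 (0.22 log units; within the scatter) and so does not separate the two groups, while a 1.1-fold higher number from compound 1 to compound 3 (0.03 log units; within the scatter) likewise leaves the 4-methylphenyl and 3,4-difluorophenyl compounds indistinguishable. All three ring patterns therefore read alike here, and no measurement is available to say why.

Still open, on these data alone, is whether a group of a different kind at this place, such as an amine or a carboxylic acid, would shift the number beyond the scatter.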